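The source may report more compounds than this note shows. Statements on the series, on what has been measured and on what is new or still open speak of the compounds shown alone.

Of the compounds shown here, three sharing one core have been tested in a functional assay on MIA PaCa-2 cells (Homo sapiens) for inhibition, read by MTT assay, with a stated time of 3 days; a higher number here means a weaker inhibitor, a lower number a stronger inhibitor. Compound 1 `O=C([C@@H]1CCCN(S(=O)(=O)c2ccc(S(=O)(=O)C3CCC3)cc2)C1)N1CCC(F)(F)CC1` gives 12.6 nM, compound 2 `CCN(CC)S(=O)(=O)c1ccc(S(=O)(=O)N2CCC[C@@H](C(=O)N3CCC(O)CC3)C2)cc1` gives 230 nM, and compound 3 `CCN(CC)S(=O)(=O)c1ccc(S(=O)(=O)N2CCC[C@@H](C(=O)N[C@H]3CC[C@H](OC)CC3)C2)cc1` gives 2290 nM, the highest of the three numbers. The nearest number to compound 3 is that of compound 2, and the step of a 10-fold higher number from compound 2 to compound 3 (1.00 log units; beyond the scatter) lies beyond the scatter. Compound 4 `CCN(CC)S(=O)(=O)c1ccc(S(=O)(=O)N2CCC[C@@H](C(=O)N3CCC(C(F)F)CC3)C2)cc1` differs from compound 3 only on the carbonyl carbon: 4-(difluoromethyl)piperidin-1-yl in place of (4-methoxycyclohexyl)amino on a carbonyl carbon. Among the compounds with values here, the single measured step that bears on this change, a 10-fold higher number from compound 2 to compound 3 (1.00 log units; beyond the scatter), runs in the opposite direction, from a piperidine amide to the (4-methoxycyclohexyl)amino amide, so a return toward the lower numbers of this assay is expected, a 19-fold lower number from compound 3 to compound 4 (1.28 log units; beyond the scatter). Compound 4 is therefore estimated at 120 nM, with a range from 30 nM to 500 nM.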

Compound 4, half-maximal inhibitory concentration: 140 nM
The estimate for compound 4 lay 1.2-fold (0.07 log units) below the measured number; low and high end bracket the measured number.
By their numbers in this assay, from the lowest: compound 1; then compounds 4 and 2 (each within the scatter of the next); then compound 3.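

Placing 4-(difluoromethyl)piperidin-1-yl on the carbonyl carbon instead of (4-methoxycyclohexyl)amino gives a 16-fold lower number from compound 3 to compound 4 (1.21 log units; beyond the scatter), so the loss seen with compound 3 is not shared by this piperidine amide. With the piperidine amide kept, difluoromethyl in place of hydroxy gives a 1.6-fold lower number from compound 2 to compound 4 (0.22 log units; within the scatter), so these two groups cannot be told apart in this cell read-out. No measurement shown gives a reason for the large step. Still open, from the compounds shown here alone, is how an amine or a carboxylic acid would behave in place of difluoromethyl on this ring.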